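This account rests on a few compounds, and the source may have more. Where it says the series, first, only, none or still open, it means among the compounds named here.

Compound 1 `CCC(=O)Nc1ccc(S(=O)(=O)Oc2ccccc2C(C)C)cc1` and compound 2 `CC(C)C(=O)Nc1ccc(S(=O)(=O)Oc2ccccc2C(C)C)cc1` share one core and differ only in the acyl group on the amide nitrogen. In a functional assay on M21 cells (Homo sapiens) for antiproliferative activity, read by sulforhodamine B assay, with a stated time of 48 h (a higher number here means a weaker inhibitor, a lower number a stronger inhibitor), compound 1 gives 11000 nM, and compound 2 gives 11000 nM. The step of no change at the digits printed from compound 1 to compound 2 (within the scatter) shows that this change, a methyl in place of hydrogen on a saturated chain carbon bound to a carbonyl carbon and a saturated chain carbon, left the read-out where it was, so compound 2 stands level with compound 1.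

Compound 3 `CC(C)c1ccccc1OS(=O)(=O)c1ccc(NC(=O)CCCCl)cc1` is the next member. Its difference from compound 2 is 3-chloropropyl in place of isopropyl on a carbonyl carbon, a 3-chloropropyl in place of isopropyl on a carbonyl carbon. Among the measured compounds shown here, the only measured step that bears on an acyl change here, no change at the digits printed from compound 1 to compound 2 (within the scatter), was within the scatter, so the expected step of no change at the digits printed from compound 2 to compound 3 (within the scatter) is none beyond the scatter. Compound 3 is therefore estimated at 11000 nM, with a range from 4000 nM to 30000 nM.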

Compound 3, half-maximal inhibitory concentration: 5100 nM
For compound 3 the middle estimate is 2.2-fold (0.33 log units) above the measured one, within the range that was stated.
By their numbers in this assay, from the lowest: compound 3; then compounds 1 and 2 (each within the scatter of the next).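

In this assay the acyl group on the amide nitrogen proves able to move the read-out: the data show a 2.2-fold lower number from compound 2 to compound 3 (0.33 log units; beyond the scatter) when 3-chloropropyl replaces isopropyl on a carbonyl carbon, and a 2.2-fold lower number from compound 1 to compound 3 (0.33 log units; beyond the scatter) when chloromethyl takes the place of hydrogen on a saturated chain carbon, two bonds along the chain from a carbonyl carbon. These steps are modest, but unlike the methyl change that links compound 1 and compound 2, they lie beyond the scatter. No measurement offered here accounts for them.

On these data alone, whether the chlorine or the chain length carries the step stays open, and a propyl chain without chlorine or a 3-aminopropyl group on that carbonyl carbon would speak to it. As far as these compounds go, how a longer chain would read in this assay also remains open.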